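Replacing the hydroxyethyl arm on the ring nitrogen

The source may report more compounds than this note shows. Statements on the series, on what has been measured and on what is new or still open speak of the compounds shown alone.

Compound 1 `CCCCNc1nc(-c2ccccc2)c(Cc2c(O)ccc3ccccc23)c(=O)[nH]1` and compound 2 `O=c1[nH]c(NCCO)nc(-c2ccccc2)c1Cc1c(O)ccc2ccccc12` share one core and differ only in the group on the ring nitrogen. In a functional assay on RT-112 cells (Homo sapiens) for antiproliferative activity, read by MTT assay, with a stated time of 24 h (a lower number here means a stronger inhibitor, a higher number a weaker inhibitor), compound 1 gives 1600 nM, and compound 2 gives 96600 nM. Compound 2 thus stands at the higher of the two numbers, with a 60-fold higher number from compound 1 to compound 2 (1.78 log units; beyond the scatter) separating it from compound 1. Compound 3 `COc1ccc(Nc2nc(-c3ccccc3)c(Cc3c(O)ccc4ccccc34)c(=O)[nH]2)cc1` carries 4-methoxyphenyl in place of 2-hydroxyethyl on a nitrogen on an aromatic ring. Among the compounds with values here, no measured step covers this exact exchange; the only step on this nitrogen, a 60-fold higher number from compound 1 to compound 2 (1.78 log units; beyond the scatter), shows that the group there moves the number strongly, and compound 2, carrying the leaving 2-hydroxyethyl, sits at the weak end of that step. Since the 4-methoxyphenyl that enters is wholly unlike the 2-hydroxyethyl that leaves, a move away from the weak end is expected, and the step expected in this assay is a 32-fold lower number from compound 2 to compound 3 (1.51 log units; beyond the scatter), downward, though without a measured aryl example the size is uncertain. Compound 3 is estimated at 3000 nM in this assay, with a range from 600 nM to 20000 nM.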

Compound 3, half-maximal inhibitory concentration: 138000 nM
For compound 3 the middle estimate is 46-fold (1.66 log units) below the measured one; measured number outside the range, above it.
By their numbers in this assay, from the lowest: compound 1; then compounds 2 and 3 (each within the scatter of the next).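

In this assay the exchange of 2-hydroxyethyl for 4-methoxyphenyl on the nitrogen gives a 1.4-fold higher number from compound 2 to compound 3 (0.15 log units; within the scatter) and so leaves compounds 2 and 3 indistinguishable, even though the entering group brings a six-membered aromatic ring and no hydrogen-bond donor. The exchange of butyl for 4-methoxyphenyl gives an 86-fold higher number from compound 1 to compound 3 (1.94 log units; beyond the scatter) as a large step, of the same order as a 60-fold higher number from compound 1 to compound 2 (1.78 log units; beyond the scatter) in the same direction. Among the three compounds, a large step at this nitrogen therefore appears only in the comparisons with compound 1, and compound 3 goes against any reading that a wholly different group lifts compound 2 away from the weak end.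

No measurement at hand bears on the reason for this pattern.

The compounds leave open whether the standing of compound 1 belongs to butyl alone or extends to other saturated chains, such as propyl or hexyl. They also leave open whether an unsubstituted phenyl or a benzyl on this nitrogen would stand with compound 3 or with compound 1.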